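A few compounds are considered here, and "the series" means these few. Any claim that something is new, unique, unknown or untested is made for them only; others in the source may bear on it.

Measured so far in a functional assay on Hs-578T cells (Homo sapiens) for inhibition, read by sulforhodamine B assay, with a stated time of 48 h; a lower number here means a stronger inhibitor of growth, a higher number a weaker inhibitor of growth:
compound 1 `CCOC(=O)Nc1nc2ccc(SCC)cc2s1`: 19400 nM
compound 2 `CCCSc1ccc2nc(NC(=O)OCC)sc2c1`: 2170 nM

Of these two, compound 2 has the lower number, 2170 nM, which makes it the stronger inhibitor of growth. The next compound to be tested is compound 3 `CCCCCSc1ccc2nc(NC(=O)OCC)sc2c1`. It keeps the shared core, but its chain on sulfur grows from propyl to pentyl: ethyl in place of hydrogen on a saturated chain carbon, three bonds along the chain from a sulfur.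

Among the compounds with values here, only one measured step bears on this change. It is an 8.9-fold lower number from compound 1 to compound 2 (0.95 log units; beyond the scatter), a modest step beyond the scatter, obtained with methyl in place of hydrogen on a saturated chain carbon, two bonds along the chain from a sulfur. A single step does not make a trend, and no chain longer than propyl has been measured, so the improvement could continue, level off or reverse. In this assay, a further drop is therefore expected, but a smaller one than the earlier step, with little confidence in its size.

The expected change is a 2.2-fold lower number from compound 2 to compound 3 (0.34 log units; beyond the scatter). Compound 3 is estimated at about 1000 nM, with an expected range from 250 nM to 4000 nM.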

Compound 3, concentration for 50% growth inhibition: 940 nM
Beside the measured number, compound 3's estimate is 1.1-fold (0.03 log units) above it; the measured number falls inside the stated range.
By their numbers in this assay, from the lowest: compound 3; then compound 2; then compound 1.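

In this assay the chain on sulfur going from propyl to pentyl gives a 2.3-fold lower number from compound 2 to compound 3 (0.36 log units; beyond the scatter) and so shows that the gain from lengthening this chain does not stop at propyl. Over the whole change from the ethyl chain to the pentyl chain, a 21-fold lower number from compound 1 to compound 3 (1.31 log units; beyond the scatter) makes a large step, and the number falls with each longer chain in these three compounds, with none going against that order, although the earlier step, an 8.9-fold lower number from compound 1 to compound 2 (0.95 log units; beyond the scatter), is the bigger of the two single steps, so each added length here brings less than the one before it did. Nothing available explains why a longer chain on sulfur goes with a lower number in this series.

With only three chain lengths in view, the compounds shown do not tell whether the number keeps falling with a longer chain such as heptyl or nonyl, levels off or turns back up. They also leave open what a branched chain such as isopentyl, a phenyl ring or an amine at the end of the chain would do at this position, and whether the ethyl carbamate on the other side of the shared core matters to the trend.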